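Bromo Replaces Methoxy: From Compound 2 to Compound 3

The source may report more compounds than this note shows. Statements on the series, on what has been measured and on what is new or still open speak of the compounds shown alone.

Compound 1 `C=C1CN/C(=N/c2ccccc2)S1` gives > 100000 nM in a functional assay on HCT-116 cells (Homo sapiens) for antiproliferative activity, read by MTT assay, with a stated time of 72 h (a higher number here means a weaker inhibitor, a lower number a stronger inhibitor), which is a limit of the assay rather than a number (the limit of > 100000 nM in this assay, at which 1 of the 2 values shown sits). Compound 2 `COc1ccc(/C=C2/CN(C)/C(=N/c3ccc(OC)cc3)S2)cc1` gives 15900 nM in this assay and so supplies the only number shown. Compound 3 `COc1ccc(/C=C2/CN(C)/C(=N/c3ccc(Br)cc3)S2)cc1` differs from compound 2 in one place: bromo in place of methoxy on an aromatic carbon. Within the data shown here, no measured pair shows the effect of such a swap here, so only a modest step is expected, in either direction or none beyond the usual scatter. Compound 3 is expected to give 12000 nM, within 4000 nM to 40000 nM. The expected step of a 1.3-fold lower number from compound 2 to compound 3 (0.12 log units; within the scatter) is therefore small.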

Compound 3, half-maximal inhibitory concentration: 8900 nM
Compound 3: middle estimate off by 1.3-fold (0.13 log units), on the high side, within the range that was stated.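

Before this pair, no measured step showed what a swap at this position does. Replacing 4-methoxyphenyl with 4-bromophenyl gives a 1.8-fold lower number from compound 2 to compound 3 (0.25 log units; within the scatter) in this assay, so the two compounds cannot be told apart, and here bromo stands in for methoxy without a readable change. Nothing measured here explains why the two groups read alike.

As far as these compounds go, whether an amine, a carboxylic acid or a longer chain on this aromatic carbon would read the same remains open. A single pair also cannot show a general pattern for this position.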